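The source may hold more compounds than are shown below. What is called first, only, known or untested is meant among the compounds shown, and "the series" means these compounds.

Compound 1 `COC(C)c1c(NC(=O)Nc2cnc(-n3nccn3)c(Cl)c2)cnc2ccccc12` and compound 3 `COC(C)c1c(NC(=O)Nc2cnc(-n3nccn3)c(Cl)c2)cnc2ccc(F)cc12` share a urea framework, and their cores differ by fluoro in place of hydrogen on an aromatic carbon. In a functional assay on OCI-Ly3 cells (Homo sapiens) for antiproliferative activity (a lower number here means that less compound is needed, a higher number that more compound is needed for the effect), compound 1 gives 620 nM, while compound 3 gives 270 nM, which amounts to a 2.3-fold lower number from compound 1 to compound 3 (0.36 log units; beyond the scatter). Compound 2 `COC(C)(C)c1c(NC(=O)Nc2cnc(-n3nccn3)c(Cl)c2)cnc2ccccc12` carries methyl in place of hydrogen on a saturated chain carbon bound to an aromatic carbon, an oxygen on a saturated carbon and a saturated chain carbon; in this assay compound 2 gives 4430 nM, and that step is a 7.1-fold higher number from compound 1 to compound 2 (0.85 log units; beyond the scatter). Compound 4 `CCOC(C)c1c(NC(=O)Nc2cnc(-n3nccn3)c(Cl)c2)cnc2ccc(F)cc12` has not been measured. It differs from compound 3 by methyl in place of hydrogen on a saturated chain carbon bound to an oxygen on a saturated carbon. Going by the values given here, this is the same kind of change as the one separating compound 1 and compound 2, but not the same: there the entering methyl sits on a saturated chain carbon bound to an aromatic carbon, an oxygen on a saturated carbon and a saturated chain carbon, whereas here it sits on a saturated chain carbon bound to an oxygen on a saturated carbon. Because the earlier step was a 7.1-fold higher number from compound 1 to compound 2 (0.85 log units; beyond the scatter), a higher number is expected. Since the place differs, compound 4 is expected to take a smaller step, a 2.0-fold higher number from compound 3 to compound 4 (0.31 log units; beyond the scatter). Compound 4 is thus estimated to give about 550 nM in this assay, with a likely range from 220 nM to 1500 nM.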

Compound 4, half-maximal effective concentration: 590 nM
Compound 4: middle estimate off by 1.1-fold (0.03 log units), on the low side; the range from low to high includes it.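

In this assay, the added methyl gives a 2.2-fold higher number from compound 3 to compound 4 (0.34 log units; beyond the scatter), so the direction of the earlier step recurs, but its size does not carry over unchanged: the same change on two cores in this assay, a 7.1-fold higher number (0.85 log units; beyond the scatter) from compound 1 to compound 2 and a 2.2-fold higher number (0.34 log units; beyond the scatter) from compound 3 to compound 4, 3.3-fold (0.51 log units) apart, beyond the scatter of two such steps. These two pairs agree in direction only, and one such agreement makes no rule for the series. The pairs also do not show that the core accounts for the gap: one methyl enters on a saturated chain carbon bound to an aromatic carbon, an oxygen on a saturated carbon and a saturated chain carbon, the other on a saturated chain carbon bound to an oxygen on a saturated carbon, so place and core change together.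

The compounds shown leave open how the 1-ethoxyethyl group behaves on the core of compound 1, which would separate place from core. They also leave open whether a longer chain such as propoxy would continue the rise, and how an amine in place of the ether oxygen would compare.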